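Swapping Bromine for Methyl on the Pyridine Core

The source may hold more compounds than are shown below. What is called first, only, known or untested is meant among the compounds shown, and "the series" means these compounds.

Measured compounds:
- compound 1, `O=C(Nc1nn[nH]n1)c1cc(Br)ccn1`: 9%
- compound 2, `Cc1ccc(C)c(C(=O)Nc2nn[nH]n2)n1`: 37%
- compound 3, `Cc1cccc(C(=O)Nc2nn[nH]n2)n1`: 40%

In a functional assay on the whole organism for inhibition, with Rattus norvegicus as the target, at a dose of 1 mg/kg by the oral route (a lower number here means a weaker effect, a higher number a stronger effect of the compound at the dose given), compound 1 gives 9%, the lowest of the three numbers. Compound 2 and compound 3 both sit well above it, beyond the scatter, and their own values lie within the scatter of each other. Within the data shown here, the one measured step between them, a number 3 percentage points higher from compound 2 to compound 3 (within the scatter), shows that taking away a methyl group on the aromatic carbon changes little.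

Compound 4, `Cc1ccnc(C(=O)Nc2nn[nH]n2)c1`, has not yet been measured in this assay. It differs from compound 1 in one place: methyl in place of bromo on an aromatic carbon. Among the measured compounds shown here, no measured pair shows a bromo-to-methyl exchange directly, so the step from compound 2 to compound 3 bears on it only loosely, by showing that a methyl group on this core is tolerated. The more telling point is that compound 2 and compound 3, which carry methyl groups, sit far above compound 1, which carries bromo.

The expectation for compound 4 is therefore a rise in this assay of about a number 21 percentage points higher from compound 1 to compound 4 (beyond the scatter), with considerable uncertainty. Compound 4 is estimated at 30%, within a range from 10% to 50%.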

Compound 4, a percentage reported as inhibition, in the whole organism at one dose (the size of the read-out at that dose, not a potency): 28%
Beside the measured number, compound 4's estimate is 2 percentage points above it; measured number inside the range.
By their numbers in this assay, from the lowest: compound 1; then compounds 4, 2 and 3 (each within the scatter of the next, the first and the last beyond it).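

Before this result, bromo and methyl could only be compared across compounds that differ in more than one place. Compound 1 and compound 4 now isolate the exchange at a single position, on the aromatic carbon opposite the ring nitrogen. In this assay, this one change gives a number 19 percentage points higher from compound 1 to compound 4 (beyond the scatter), so the swap alone produces a modest gain in effect at the dose given, with the rest of the molecule held constant. No measurement shown here bears on why the methyl compound gives the larger effect.

The pair also cannot show whether bromo lowers the effect, methyl raises it, or both, and a plain hydrogen at this position would be needed to separate these possibilities. From the compounds shown here alone, it remains open how other groups would fare on this same carbon, such as an amine, a carboxylic acid or a longer chain like propyl, and so whether methyl is a particularly good choice here or simply one of many groups that would give a similar result.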